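From isopropyl to pentan-3-yl on a carbonyl carbon

The source may hold more compounds than are shown below. What is called first, only, known or untested is meant among the compounds shown, and "the series" means these compounds.

Among the measured compounds shown here, in a physicochemical assay for pharmacokinetics, read by HPLC, in phosphate buffer, at pH 7.4 (on this read-out lower numbers stand for a shorter-lived compound and higher numbers for a longer-lived compound), compound 1 `CCCC(CCC)C(=O)N(C)/N=N/c1ccc(C)cc1` gives 31.3 h, the only exact number so far. Compound 2 `CCCC(=O)N(C)/N=N/c1ccc(C#N)cc1` gives > 40 h, which is a limit of the assay and not a number. On these data alone, compound 3 `CC(C)C(=O)N(C)/N=N/c1ccc(C#N)cc1` gives > 40 h, which is also a limit, so its true half-life stays unknown. The data so far stop at the limit of > 40 h in this assay, at which 2 of the 3 values shown sit.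

Compound 4 `CCC(CC)C(=O)N(C)/N=N/c1ccc(C#N)cc1` has not yet been measured. It carries pentan-3-yl in place of isopropyl on a carbonyl carbon.

For the measured compounds named here, the one measured step at this same place, isopropyl in place of propyl on a carbonyl carbon, is a step that the two limits leave unreadable from compound 2 to compound 3. It therefore gives neither a size nor a direction to build on. Going by the values given here, compound 3 differs from compound 1 in more than one place, so the 31.3 h of compound 1 offers no clean step either.

With nothing pointing either way, the expected change in this assay is a step that the limit leaves unreadable from compound 3 to compound 4, an estimate of no shift beyond the usual scatter. A limit is again a likely result for compound 4. If a number is obtained, the estimate for compound 4 is 50 h, with an expected range from 28 h to 100 h.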

Compound 4, half-life: > 40 h
Compound 4 ended at the assay's limit (the forecaster's own chance of this, stated with the estimate: 65%); the middle value does not contradict the limit.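

In this assay no step can be read among compound 2, compound 3 and compound 4, because all three sit at a limit of the assay and not at a number: the limit of > 40 h in this assay, at which 3 of the 4 values shown sit.

The compounds shown leave open the true half-lives of these three compounds, and whether pentan-3-yl in place of isopropyl on a carbonyl carbon changes the half-life at all.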